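A few compounds are considered here, and "the series" means these few. Any claim that something is new, unique, unknown or untested is made for them only; others in the source may bear on it.

In a functional assay on HL-60 cells (Homo sapiens) for cytotoxicity, read by MTT assay, with a stated time of 48 h (a higher number here means a weaker inhibitor, a lower number a stronger inhibitor), compound 1 `COc1ccc(-c2c[nH]c(=O)n2-c2cc(OC)c(OC)c(OC)c2)cc1` gives 19800 nM. Compound 2 `COc1ccc(-c2c[nH]c(=O)n2-c2cc(OC)c(OC)c(OC)c2)cc1OC` differs from it in one spot, (methoxy in place of hydrogen on an aromatic carbon), and in this assay compound 2 gives 38800 nM, which is a 2.0-fold higher number from compound 1 to compound 2 (0.29 log units; within the scatter). Compound 3 `COc1ccc(-c2cn(C(=O)Nc3cc(OC)c(OC)c(OC)c3)c(=O)n2-c2cc(OC)c(OC)c(OC)c2)cc1` has a different core; the difference between the two cores is not broken down here. In this assay compound 3 gives 5400 nM, a number that lies beyond the scatter from both compound 1 and compound 2. Compound 4 `COc1ccc(-c2cn(C(=O)Nc3cc(OC)c(OC)c(OC)c3)c(=O)n2-c2cc(OC)c(OC)c(OC)c2)cc1OC` is made from compound 3 by the same change, (methoxy in place of hydrogen on an aromatic carbon). Because a 2.0-fold higher number from compound 1 to compound 2 (0.29 log units; within the scatter) stayed within the scatter, a step of similar size is expected for this change on the new core. Compound 4 is therefore expected to show a 1.6-fold higher number from compound 3 to compound 4 (0.20 log units; within the scatter). The estimate for compound 4 is 8500 nM, with a likely range from 3500 nM to 20000 nM.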

Compound 4, half-maximal inhibitory concentration: 6500 nM
Compound 4: the middle estimate sits 1.3-fold (0.12 log units) above what was measured, within the range that was stated.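

In this assay, going from 4-methoxyphenyl to 3,4-dimethoxyphenyl on the core of compound 3 gives a 1.2-fold higher number from compound 3 to compound 4 (0.08 log units; within the scatter), so the added methoxy has no effect that can be told apart from the scatter. Set beside the same change on the core of compound 1, the two steps agree: the same change on two cores in this assay, a 2.0-fold higher number (0.29 log units; within the scatter) from compound 1 to compound 2 and a 1.2-fold higher number (0.08 log units; within the scatter) from compound 3 to compound 4, 1.6-fold (0.21 log units) apart, within the scatter of two such steps. On these two cores, then, the change behaves alike, but this rests on just two pairs of compounds, and since neither step stands out from the scatter, it does not show that a change with a clear effect would carry across, or that other cores would behave the same way.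

Still open, from the compounds shown here alone, is what a different group would do at this spot on the ring, such as a hydroxyl, an amine or a longer chain like ethoxy.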